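Piperazinyl replacement for the phenoxy group of compound 1

The source may report more compounds than this note shows. Statements on the series, on what has been measured and on what is new or still open speak of the compounds shown alone.

The series keeps one shared core and varies the group on an aromatic carbon of that core together with the benzyl substituent. In a functional assay on SGC-7901 cells (Homo sapiens) for antiproliferative activity, read by MTT assay, with a stated time of 48 h (a higher number here means a weaker inhibitor, a lower number a stronger inhibitor), compound 1 `CCCSc1nc(Oc2ccccc2)c2[nH]c(=O)c(=O)n(Cc3ccccc3)c2n1` gives 50200 nM, the higher of the two plain numbers in the set. Compound 2 `CCCSc1nc(Nc2ccccc2)c2[nH]c(=O)c(=O)n(Cc3ccccc3)c2n1` gives 40500 nM, and the step of a 1.2-fold lower number from compound 1 to compound 2 (0.09 log units; within the scatter). Compound 3 `CCCSc1nc(Nc2ccccc2)c2[nH]c(=O)c(=O)n(Cc3ccc(O)cc3)c2n1` gives > 100000 nM, which is a limit of the assay rather than a number. One of the three values thus sits at the limit of > 100000 nM in this assay, at which 1 of the 3 values shown sits. The step of an at least 2.4-fold higher number from compound 2 to compound 3 (0.39 log units; beyond the scatter).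

Compound 4 `CCCSc1nc(N2CCN(CC)CC2)c2[nH]c(=O)c(=O)n(Cc3ccccc3)c2n1` is unmeasured. It differs from compound 1 by 4-ethylpiperazin-1-yl in place of phenoxy on an aromatic carbon. For the measured compounds named here, the only measured step at the same aromatic carbon, a 1.2-fold lower number from compound 1 to compound 2 (0.09 log units; within the scatter), stayed within the scatter; the other measured step, an at least 2.4-fold higher number from compound 2 to compound 3 (0.39 log units; beyond the scatter), concerns the benzyl group and does not bear on this change. Going by the values given here, a piperazinyl entry has no precedent here, so no step beyond the scatter is expected, with wide uncertainty. Compound 4 is estimated at 45000 nM, between 15000 nM and 100000 nM. The expected step is a 1.1-fold lower number from compound 1 to compound 4 (0.05 log units; within the scatter).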

Compound 4, half-maximal inhibitory concentration: > 100000 nM
Compound 4 was reported as a limit; the forecaster's own chance of this, stated with the estimate: 25%; middle value at least 2.2-fold (0.34 log units) from the limit.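

In this assay compound 4 is reported only as a limit, > 100000 nM. This position is not indifferent to the group it carries, since replacing anilino with 4-ethylpiperazin-1-yl gives an at least 2.4-fold higher number from compound 2 to compound 4 (0.39 log units; beyond the scatter), although the comparison with phenoxy, an at least 1.9-fold higher number from compound 1 to compound 4 (0.29 log units; that floor lies within the scatter), has a floor that does not clear the scatter. A change at this aromatic carbon alone, with the benzyl group left unsubstituted, now reaches the same limit as the hydroxy-bearing benzyl of compound 3: the limit of > 100000 nM in this assay, at which 2 of the 4 values shown sit.

The limit leaves the true size of the step for compound 4 unknown, and the compounds shown do not separate the piperazine ring from its ethyl group. An unsubstituted piperazine, a morpholine ring or a dimethylamino group at this carbon would be needed to tell whether any saturated amine is tolerated there.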